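The compounds below may be only part of what the source reports. "The series", "measured", "known", "first", "only" and "open" are said of these compounds alone.

Compounds measured so far:
- Compound 1, `Cc1cc(C(F)(F)F)cc(NC[C@@H]2CC3(CC3)CN2C(=O)c2nc(C)sc2-c2ccccc2)n1`, gives 7.8 in a functional assay on CHO cells for antagonist activity at Orexin/Hypocretin receptor type 1 (Homo sapiens), read by FLIPR and calcium flux; on this read-out lower numbers stand for lower potency and higher numbers for higher potency (the scale is a negative logarithm).
- Compound 2, `Cc1nc(C(=O)N2CCC3(CC3)C[C@H]2CNc2ccc(C(F)(F)F)cn2)c(-c2ccccc2)s1`, gives 7.7 in this assay.
- Compound 3, `Cc1ccc(-c2nccs2)c(C(=O)N2CC3(CC3)C[C@H]2CNc2ccc(C(F)(F)F)cn2)n1`, gives 8.6 in this assay.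

Compound 2 carries the lowest of the three numbers; its gap to compound 1 lies within the scatter, while compound 3 stands beyond it. Compound 4, `Cc1nc(C(=O)N2CCC3(CC3)C[C@H]2CNc2ccc(Cl)cn2)c(-c2ccccc2)s1`, differs from compound 2 by chloro in place of trifluoromethyl on an aromatic carbon. Going by the values given here, no measured pair shows this change, so the expectation rests on compound 2 alone. A small step downward, barely beyond the scatter, is expected, a number 0.30 log units lower from compound 2 to compound 4 (within the scatter). Compound 4 is therefore estimated at 7.4, with a range from 6.9 to 7.9.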

Compound 4, negative logarithm of the antagonist equilibrium constant: 7.9
Estimate against measurement, compound 4: 0.50 log units below, and the stated range covers the measured number.
By their numbers in this assay, from the lowest: compounds 2, 1 and 4 (each within the scatter of the next); then compound 3.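

In this assay, going from 5-(trifluoromethyl)pyridin-2-yl to 5-chloropyridin-2-yl gives a number 0.20 log units higher from compound 2 to compound 4 (within the scatter). At this place on the ring, then, a single chlorine atom stands in for the four heavy atoms of trifluoromethyl with no difference that can be told from the scatter. The data shown offer no measurement that would explain this result.

The compounds shown leave open how a nitrile, a methoxy group or an amine would read at this place. They also leave open whether the same exchange would read alike on the core of compound 3.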